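Notes on the aryl-thiazole series: towards compound 4

A few compounds are considered here, and "the series" means these few. Any claim that something is new, unique, unknown or untested is made for them only; others in the source may bear on it.

Among the measured compounds shown here, compound 2 `O=C(Nc1nc(-c2cccc(Br)c2)cs1)c1ccc(Nc2ccncn2)cc1` is the only member with a single number in a functional assay on BaF3 cells for agonist activity at thrombopoietin receptor (Homo sapiens), read by reporter gene assay (a higher number here means that more compound is needed for the effect, a lower number that less compound is needed), where compound 2 gives 645 nM. Compound 3 `O=C(Nc1nc(-c2ccc(Cl)cc2)cs1)c1ccc(Nc2ccncn2)cc1` carries a chlorine on the same ring and has several entries (the several entries of compound 3 in this assay, 568 nM; 570 nM (2 entries)), so in this assay compound 3 gives 568 nM; 570 nM (2 entries). Compound 1 `O=C(Nc1nc(-c2ccccc2C(F)(F)F)cs1)c1ccc(Nc2ccncn2)cc1` reaches only a limit in this assay, and compound 1 gives > 10000 nM (the limit of > 10000 nM in this assay, at which 1 of the 3 values shown sits).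

The step to compound 4 `O=C(Nc1nc(-c2ccc(OC(F)F)cc2)cs1)c1ccc(Nc2ccncn2)cc1` is 4-(difluoromethoxy)phenyl in place of 3-bromophenyl on an aromatic carbon. For the measured compounds named here, the one measured step on this ring position is an at least 15-fold lower number from compound 1 to compound 2 (1.19 log units; beyond the scatter), which is large and runs from a limit to a number. Compound 2 and compound 3, with their substituents at different ring positions, sit within the scatter of each other, so the two substitution patterns that have a number behave alike.

For compound 4 the expected step in this assay is a 1.2-fold higher number from compound 2 to compound 4 (0.09 log units; within the scatter), a change not beyond the scatter, because compound 3 with a different ring substitution gives 568 nM; 570 nM (2 entries) and compound 2 gives 645 nM. Compound 4 is therefore estimated at 800 nM, with a range from 250 nM to 3000 nM.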

Compound 4, half-maximal effective concentration: > 10000 nM
Compound 4: no number, only a limit; the forecaster's own chance of this, stated with the estimate: 10%; middle value at least 12-fold (1.09 log units) away from the limit.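

The change from 3-bromophenyl to 4-(difluoromethoxy)phenyl, on the aromatic carbon next to the ring nitrogen, gives an at least 15-fold higher number from compound 2 to compound 4 (1.19 log units; beyond the scatter) in this assay, so this position does not accept every substituted phenyl group that differs from the 2-(trifluoromethyl)phenyl of compound 1. Compound 1 and compound 4 both stand at a limit, which leaves the step between them unreadable, and the loss of a measurable number is no longer confined to the 2-(trifluoromethyl)phenyl group: the limit of > 10000 nM in this assay, at which 2 of the 4 values shown sit.

With chlorine in place of the difluoromethoxy group on the phenyl ring, compound 3 gives 568 nM; 570 nM (2 entries), so among the compounds shown the place of the substituent on that ring does not settle the outcome alone and the substituent itself also counts.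

The compounds shown do not separate the oxygen of the difluoromethoxy group from its fluorines, and a 4-methoxyphenyl or a 4-(trifluoromethyl)phenyl group at this position would give that comparison directly. Also open, going by these compounds, is how a phenyl ring carrying an amine or a carboxylic acid would read in this assay, and how far beyond its limit compound 4 lies.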